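Swapping Benzyl for Pyridin-2-yl at the Chain Carbon

The source may report more compounds than this note shows. Statements on the series, on what has been measured and on what is new or still open speak of the compounds shown alone.

Compound 1, `O=C(O)Cc1sc(Cc2ccccc2)nc1-c1ccc(Cl)cc1`: 50%
Compound 2, `COc1ccc(C(c2ccccc2)c2nc(-c3ccc(Cl)cc3)c(CC(=O)O)s2)cc1`: 80%
Compound 3, `O=C(O)Cc1sc(C(Cc2ccccc2)c2ccccc2)nc1-c1ccc(Cl)cc1`: 50%

Of the compounds shown here, three sharing one core have been tested in an in vitro functional assay on HEK285-7 cells for antagonist activity at prostaglandin D2 receptor 2 (Homo sapiens), read by BRET and beta-arrestin recruitment; a higher number here means a larger maximal response, a lower number a smaller maximal response. Compound 3 gives 50%, level with compound 1, and together these two are the lowest of the three numbers. Compound 2 stands apart: a number 30 percentage points lower from compound 2 to compound 3 (beyond the scatter).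

Compound 4, `O=C(O)Cc1sc(C(c2ccccc2)c2ccccn2)nc1-c1ccc(Cl)cc1`, is not yet measured. It differs from compound 3 in one place: pyridin-2-yl in place of benzyl on a saturated chain carbon bound to two aromatic carbons. The earlier steps shown here at this same chain carbon bear on the question. Putting benzyl there in place of hydrogen left the number unchanged, no change at the digits printed from compound 1 to compound 3 (within the scatter), whereas a six-membered aromatic ring bound directly to that carbon lifted it, a number 30 percentage points higher from compound 1 to compound 2 (beyond the scatter), and exchanging that ring for benzyl lowered it again, a number 30 percentage points lower from compound 2 to compound 3 (beyond the scatter). Pyridin-2-yl is likewise a six-membered aromatic ring bound directly to the chain carbon, though it is a different ring from 4-methoxyphenyl, so only part of the gain seen with compound 2 may carry over. For compound 4 a modest rise is therefore expected, a number 15 percentage points higher from compound 3 to compound 4 (beyond the scatter). Compound 4 is expected to give 65%, within a range from 45% to 85%.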

Compound 4, largest response reached (reported as efficacy), in percent of the reference or control that the assay uses: 55%
The estimate for compound 4 lay 10 percentage points above the measured number; the range from low to high includes it.
By their numbers in this assay, from the lowest: compounds 1, 3 and 4 (each within the scatter of the next); then compound 2.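

In this assay, a six-membered aromatic ring bound directly to the chain carbon proves not to be enough on its own to lift the number. Pyridin-2-yl in place of benzyl gives a number 5 percentage points higher from compound 3 to compound 4 (within the scatter) and pyridin-2-yl in place of hydrogen gives a number 5 percentage points higher from compound 1 to compound 4 (within the scatter) and so leaves compound 4 level with the two lower compounds. Set against 4-methoxyphenyl, the same group gives a number 25 percentage points lower from compound 2 to compound 4 (beyond the scatter) and thus ties the higher number among these four compounds to 4-methoxyphenyl alone, not to directly bound aromatic rings in general, although no evidence at hand gives a reason for the gap between these two rings.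

On these data alone, what remains open is which part of 4-methoxyphenyl matters: a plain phenyl group at this carbon would show what the ring does without its methoxy group, and 4-hydroxyphenyl or 4-ethoxyphenyl would test how far that oxygen-bearing group can be changed. Pyridin-3-yl and pyridin-4-yl would likewise show whether moving the ring nitrogen changes the picture seen with pyridin-2-yl.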